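Adding a Methyl on Two Different Side Chains

This account rests on a few compounds, and the source may have more. Where it says the series, first, only, none or still open, it means among the compounds named here.

Compound 1 `COc1cc(Cl)c(-c2nc(SCC(=O)NC3CC3)nc3[nH]cc(C#N)c23)cc1OC` was tested in a functional assay on HCT-116 cells (Homo sapiens) for antiproliferative activity, read by sulforhodamine B assay, with a stated time of 4 days (a lower number here means a stronger inhibitor of growth, a higher number a weaker inhibitor of growth), where compound 1 gives 60 nM. Compound 2 `CCOc1cc(-c2nc(SCC(=O)NC3CC3)nc3[nH]cc(C#N)c23)c(Cl)cc1OC` carries methyl in place of hydrogen on a saturated chain carbon bound to an oxygen on an aromatic ring and in this assay compound 2 gives 20 nM, so that a 3.0-fold lower number from compound 1 to compound 2 (0.48 log units; beyond the scatter). Compound 3 `COc1cc(Cl)c(-c2nc(SCC(=O)NC(C)C)nc3[nH]cc(C#N)c23)cc1O` has a different core; the difference between the cores of compound 1 and compound 3 is not broken down here. In this assay compound 3 gives 238 nM, the highest of the three numbers. Compound 4 `COc1cc(Cl)c(-c2nc(SCC(=O)NC(C)(C)C)nc3[nH]cc(C#N)c23)cc1O` differs from compound 3 by methyl in place of hydrogen on a saturated chain carbon bound to an amide-type nitrogen and two saturated chain carbons. This is the same kind of change as that from compound 1 to compound 2, but not the same: there the carbon was bound to an oxygen on an aromatic ring, here to an amide-type nitrogen and two saturated chain carbons. Among the compounds with values here, no measured pair shows this change at this place, so the expected step of a 1.3-fold lower number from compound 3 to compound 4 (0.10 log units; within the scatter) in this assay is taken as smaller than the step of a 3.0-fold lower number from compound 1 to compound 2 (0.48 log units; beyond the scatter). Compound 4 is accordingly expected to give 190 nM in this assay, estimated between 70 nM and 550 nM.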

Compound 4, concentration for 50% growth inhibition: 117 nM
Compound 4: middle estimate off by 1.6-fold (0.21 log units), on the high side; measured number inside the range.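

In this assay, the change from isopropylcarbamoyl to (tert-butyl)carbamoyl gives a 2.0-fold lower number from compound 3 to compound 4 (0.31 log units; beyond the scatter), and set beside the earlier methyl addition, this step does not differ from it: the same change on two cores in this assay, a 3.0-fold lower number (0.48 log units; beyond the scatter) from compound 1 to compound 2 and a 2.0-fold lower number (0.31 log units; beyond the scatter) from compound 3 to compound 4, 1.5-fold (0.17 log units) apart, within the scatter of two such steps. Within these two pairs, then, methyl in place of hydrogen on a saturated chain carbon goes with a lower number each time, although the carbon that carries it is a different one in each pair. This does not show that the step at either place would carry over to the other core, as the compounds shown hold each place on one core only, and two pairs set no rule.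

As far as these compounds go, it remains open how a longer chain such as propoxy, in place of the ethoxy of compound 2, would read. The same holds for an amine or a carboxylic acid in place of the tert-butyl of compound 4.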